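A larger amide on the shared core

A few compounds are considered here, and "the series" means these few. Any claim that something is new, unique, unknown or untested is made for them only; others in the source may bear on it.

Two compounds stand measured in an assay on isolated protein for inhibition of Rho-associated protein kinase 1 (Homo sapiens), read by scintillation counting, radiometric assay and 33P incorporation, with a stated time of 40 min, in the presence of a further agent that is not named here; on this read-out lower numbers stand for stronger inhibition and higher numbers for weaker inhibition. Compound 1 `COc1cccc(OCC(=O)Nc2cccc(NC(=O)c3ccc(N(C)C)cc3)c2)c1` gives > 10000 nM in this assay, which is a limit rather than a number (the limit of > 10000 nM in this assay, at which 1 of the 2 values shown sits). Going by the values given here, compound 2 `CC(=O)Nc1cccc(NC(=O)COc2ccc3c(=O)ccoc3c2)c1` gives 2500 nM in this assay; this is the only number among the values shown. Among the compounds with values here, no step between the two measured compounds is given, since they differ in more than one place, so compound 1 and compound 2 show only their two values side by side.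

Compound 3 `O=C(COc1ccc2c(=O)ccoc2c1)Nc1cccc(NC(=O)c2ccc(Br)cc2)c1` has not yet been measured. It differs from compound 2 in one place: 4-bromophenyl in place of methyl on a carbonyl carbon. The step of a 1.4-fold higher number from compound 2 to compound 3 (0.15 log units; within the scatter) is expected to stay within the scatter or to run somewhat towards weaker inhibition. The estimate for compound 3 in this assay is 3500 nM, with a range from 800 nM to 15000 nM.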

Compound 3, half-maximal inhibitory concentration: 303 nM
Beside the measured number, compound 3's estimate is 12-fold (1.06 log units) above it; the whole stated range lies above it.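

In this assay, going by these compounds alone, 4-bromophenyl in place of methyl on a carbonyl carbon gives an 8.3-fold lower number from compound 2 to compound 3 (0.92 log units; beyond the scatter), which is the first step that can be read at any position. It shows that this place on the shared core takes a group of 7 heavy atoms with a six-membered aromatic ring, and that the number falls rather than rises with that change. No measurement shown bears on why the number falls.

From the compounds shown here alone, a single step cannot separate the share of the ring from that of the bromine, so it remains open how a phenyl without the bromine would read. Also open, going by these compounds, is whether a carboxylic acid or an amine in place of the bromine, or a longer chain in place of the ring, would keep the lower number.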